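The compounds below may be only part of what the source reports. "The series", "measured", "known", "first", "only" and "open" are said of these compounds alone.

Measured so far in an in vitro ADME assay on S9 fraction from liver (Rattus norvegicus, strain Wistar) for metabolic stability, read by HPLC, tested at 1 uM; on this read-out lower numbers stand for a shorter-lived compound and higher numbers for a longer-lived compound:
- compound 1 `CCCCCCNC(=O)Oc1cccc(-c2ccccc2)c1`: 0.133 h
- compound 2 `NC(=O)c1cccc(-c2cccc(OC(=O)NCCCCc3ccccc3)c2)c1`: 0.782 h
- compound 3 `O=C(NCc1cccc2ccccc12)Oc1cccc(-c2ccccc2)c1`: 0.78 h

Compound 1 holds the lowest of the three half-lives in this assay, with both compound 2 and compound 3 sitting well beyond the scatter above it; compound 2 and compound 3 lie within the scatter of each other, so no order between those two can be read.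

The next compound, compound 4 `O=C(NCCCCCCc1ccccc1)Oc1cccc(-c2ccccc2)c1`, is built from compound 1 by a single change: phenyl in place of hydrogen on a saturated chain carbon, six bonds along the chain from an amide-type nitrogen. Within the data shown here, no measured pair in the set repeats exactly this change, so the size of the step must be guessed. Compound 2 also carries a phenyl at the end of its carbamate chain and gives the higher value 0.782 h, but it differs from compound 1 in more than one place, so it is only a loose pointer. Compound 3, with a larger aromatic group at the nitrogen, likewise sits high.

The expected step in half-life from compound 1 to compound 4 is a moderate rise, a 2.3-fold higher number from compound 1 to compound 4 (0.35 log units; beyond the scatter), though a result within the scatter would not surprise. The estimate for compound 4 is 0.3 h, with a range of 0.1 h to 0.9 h.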

Compound 4, half-life: 0.657 h
The estimate for compound 4 lay 2.2-fold (0.34 log units) below the measured number; measured number inside the range.
By their numbers in this assay, from the lowest: compound 1; then compounds 4, 3 and 2 (each within the scatter of the next).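

In this assay the series gives its first reading of a change made in one place: phenyl in place of hydrogen on a saturated chain carbon, six bonds along the chain from an amide-type nitrogen, produces a 4.9-fold higher number from compound 1 to compound 4 (0.69 log units; beyond the scatter) on an otherwise unchanged structure. The step lies beyond the scatter, so at this position the added six-membered aromatic ring goes with a longer half-life and not a shorter one, while the change brings in no hydrogen-bond donors, no hydrogen-bond acceptors and no net charge. Nothing at hand bears on why the half-life moves with this change.

With one matched pair, the size of this step cannot be called typical of the position, nor can it be separated into a contribution of the ring and a contribution of the added carbon atoms. From the compounds shown here alone, whether a cyclohexyl group, a pyridine ring or a carboxylic acid on the same chain carbon would move the half-life the same way remains open, as does whether phenyl gives a step of this size on a shorter chain.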